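This account rests on a few compounds, and the source may have more. Where it says the series, first, only, none or still open, it means among the compounds named here.

The three measured compounds in a functional assay on CHO cells for inhibition of Orexin receptor type 2 (Homo sapiens), read by FLIPR and calcium flux (on this read-out higher numbers stand for weaker inhibition and lower numbers for stronger inhibition), are these. Compound 1 `CCN(CC)C(=O)CN(c1cc(C(C)C)ccc1Cl)S(=O)(=O)c1ccc(OC)c(OC)c1` gives 90 nM. Compound 2 `CCN(CC)C(=O)CN(c1ccc(C)cc1)S(=O)(=O)c1cccc(C)c1` gives 60 nM. Compound 3 `CCN(CC)C(=O)CN(c1cc(N(C)C)ccc1OC)S(=O)(=O)c1ccc(OC)c(OC)c1` gives 239 nM.

Compound 2 has the lowest number of the three. Its gap to compound 1 is within the usual scatter, so the two cannot be ranked against each other; its gap to compound 3 is beyond the scatter. Going by the values given here, the only step among the measured compounds that changes one place is a 2.7-fold higher number from compound 1 to compound 3 (0.42 log units; beyond the scatter), and that change sits on the aryl group attached to the sulfonamide nitrogen, not on the sulfonyl aryl group.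

Compound 4 `CCN(CC)C(=O)CN(c1ccc(C)cc1)S(=O)(=O)c1cccc(Cl)c1` differs from compound 2 in a single place: chloro in place of methyl on an aromatic carbon. Among the compounds with values here, no measured step touches the sulfonyl aryl group, so nothing among the three compounds bears directly on this change, and the expectation rests on compound 2 alone. The step of no change at the digits printed from compound 2 to compound 4 (within the scatter) is therefore expected to stay within the scatter, with no clear direction. Compound 4 is estimated at 60 nM, with a range from 25 nM to 150 nM in this assay.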

Compound 4, half-maximal inhibitory concentration: 139 nM
Compound 4: middle estimate off by 2.3-fold (0.36 log units), on the low side; the measured number falls inside the stated range.
By their numbers in this assay, from the lowest: compounds 2, 1, 4 and 3 (each within the scatter of the next, the first and the last beyond it).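

Going by these compounds alone, this is the first measured step on the sulfonyl aryl group, and it shows that the group at this place is not indifferent in this assay: a 2.3-fold higher number from compound 2 to compound 4 (0.36 log units; beyond the scatter), with chloro in place of methyl. Neither group carries a ring, a hydrogen-bond donor, a hydrogen-bond acceptor or a net charge, so a modest step beyond the scatter arises here without any change in those counts. No measurement at hand says why the number moves with this change.

Within the data shown here, whether the same step would appear with another aryl group on the sulfonamide nitrogen, such as the one in compound 1, stays open. Also open, from the compounds shown here alone, is how a nitrile, an amine or a longer chain would read at this place, and whether any such group would give a lower number than methyl does.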